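The source may hold more compounds than are shown below. What is called first, only, known or untested is meant among the compounds shown, and "the series" means these compounds.

Measured in a physicochemical assay for solubility, read by nephelometry; on this read-out lower numbers stand for lower solubility and higher numbers for higher solubility:
- Compound 1 `CC1(C)C(=O)N(c2ccc(SC(F)(F)F)cc2)C(=O)N1Cc1ccncc1` gives < 0.02 ug/mL (a limit)
- Compound 2 `CC1(C)C(=O)N(c2ccc(SC(F)(F)F)cc2)C(=O)N1Cc1ccnc(NCc2ccccc2)c1` gives < 0.026 ug/mL (a limit)

Compound 2 has no number to stand on in this assay. Its reading of < 0.026 ug/mL is a limit. Compound 1 likewise gives only a limit, < 0.02 ug/mL.

Compound 3 `CNC(=O)c1cc(CN2C(=O)N(c3ccc(SC(F)(F)F)cc3)C(=O)C2(C)C)ccn1` carries methylcarbamoyl in place of benzylamino on an aromatic carbon, next to the ring nitrogen and meta to a large group: methylcarbamoyl in place of benzylamino on an aromatic carbon.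

For the measured compounds named here, the one measured step involving benzylamino is a step that the two limits leave unreadable from compound 1 to compound 2. That step offers no size to carry over, so no shift beyond the scatter is expected in this assay, and a further limit is quite likely. The expected change is an at least 1.1-fold higher number from compound 2 to compound 3 (0.06 log units; that floor lies within the scatter). For compound 3 the estimate is 0.03 ug/mL, with an expected range from 0.01 ug/mL to 0.2 ug/mL.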

Compound 3, solubility: < 0.023 ug/mL
Compound 3 ended at the assay's limit; the forecaster's own chance of this, stated with the estimate: 65%; middle value at least 1.3-fold (0.11 log units) from the limit.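

In this assay compound 3 gives < 0.023 ug/mL, which is a limit. For the compounds shown here, compounds 1 and 2 also give only limits, so no step among compounds 1, 2 and 3 can be read. The compounds shown leave open whether benzylamino or methylcarbamoyl moves this read-out at all.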